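Anilino ring substitution on the shared core

The source may hold more compounds than are shown below. What is called first, only, known or untested is meant among the compounds shown, and "the series" means these compounds.

Compound 1 `CC(C)c1ccc(-c2nc(SCc3cn(CC(=O)NC(=O)Nc4ccccn4)nn3)nc(Nc3ccc(Cl)cc3)c2C#N)cc1` gives 11200 nM in a functional assay on ECa-109 cells (Homo sapiens) for inhibition, read by MTT assay, with a stated time of 72 h; on this read-out higher numbers stand for weaker inhibition and lower numbers for stronger inhibition. Compound 2 `CC(C)c1ccc(-c2nc(SCc3cn(CC(=O)NC(=O)Nc4ccccn4)nn3)nc(Nc3ccccc3F)c2C#N)cc1` gives 15500 nM in this assay, and the step of a 1.4-fold higher number from compound 1 to compound 2 (0.14 log units; within the scatter) shows the two within the scatter of each other. Compound 3 `CC(C)c1ccc(Nc2nc(SCc3cn(CC(=O)NC(=O)Nc4ccccn4)nn3)nc(-c3ccc(C(C)C)cc3)c2C#N)cc1` carries the change (isopropyl in place of chloro on an aromatic carbon), from (4-chlorophenyl)amino to (4-isopropylphenyl)amino. Within the data shown here, no measured step covers this exchange; the single step so far on the anilino ring stayed within the scatter, and nothing in the data points to a direction. Compound 3 is therefore expected to show a 1.0-fold lower number from compound 1 to compound 3 (0.01 log units; within the scatter), a step not beyond the scatter. The estimate for compound 3 is 11000 nM, with a range from 4000 nM to 30000 nM.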

Compound 3, half-maximal inhibitory concentration: 2490 nM
Compound 3: the middle estimate sits 4.4-fold (0.65 log units) above what was measured; measured number outside the range, below it.
By their numbers in this assay, from the lowest: compound 3; then compounds 1 and 2 (each within the scatter of the next).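

In this assay the anilino ring proves responsive to its substituent: isopropyl in place of chloro gives a 4.5-fold lower number from compound 1 to compound 3 (0.65 log units; beyond the scatter), and 4-isopropylphenyl in place of 2-fluorophenyl gives a 6.2-fold lower number from compound 2 to compound 3 (0.79 log units; beyond the scatter), whereas compound 1 and compound 2 stayed within the scatter of each other. Nothing available here accounts for the difference made by isopropyl.

Going by these compounds, it remains open whether isopropyl itself matters, or whether a methyl, tert-butyl or cyclopropyl group on the same aromatic carbon would serve equally. An amine or a carboxylic acid there would show whether the lower number survives a different kind of group.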